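Swapping the Imidazole Arm for a Carboxylic Acid Chain

The compounds below may be only part of what the source reports. "The series", "measured", "known", "first", "only" and "open" are said of these compounds alone.

Compound 1, `Cn1ccnc1Cc1ccc2ccccc2c1O`: in an assay on RBL-1 cells with Polyunsaturated fatty acid 5-lipoxygenase (Rattus norvegicus) as the target (a higher number here means a weaker inhibitor, a lower number a stronger inhibitor), compound 1 gives 3500 nM
Compound 2, `Oc1c(Cc2cccc(Cl)c2)ccc2ccccc12`: in this assay compound 2 gives 52 nM

Among the measured compounds shown here, of the two numbers measured so far, compound 1 carries the highest one, so it is the weaker inhibitor of the pair. Compound 2 sits far below it, and the gap between the two values is well beyond the usual scatter. For the measured compounds named here, no single-change step links these two compounds, so their numbers are simply two points on the same scale.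

Compound 3, `O=C(O)CCCCc1ccc2ccccc2c1O`, has not yet been measured in this assay. It differs from compound 1 in one place: 3-carboxypropyl in place of 1-methyl-1H-imidazol-2-yl on a saturated chain carbon bound to an aromatic carbon. The shared core stays as it is.

Going by the values given here, with no measured step of this kind to lean on, the expectation rests on the position of compound 1 alone. An acid-bearing chain in place of the imidazole arm is expected to move the number by a 2.3-fold lower number from compound 1 to compound 3 (0.37 log units; beyond the scatter), a modest improvement rather than a large one. For compound 3 the estimate in this assay is therefore 1500 nM, with a plausible range from 300 nM to 8000 nM.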

Compound 3, half-maximal inhibitory concentration: 4200 nM
Beside the measured number, compound 3's estimate is 2.8-fold (0.45 log units) below it; low and high end bracket the measured number.
By their numbers in this assay, from the lowest: compound 2; then compounds 1 and 3 (each within the scatter of the next).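

At this position, on a saturated chain carbon bound to an aromatic carbon, putting 3-carboxypropyl in place of 1-methyl-1H-imidazol-2-yl gives a 1.2-fold higher number from compound 1 to compound 3 (0.08 log units; within the scatter) in this assay and so leaves the two compounds indistinguishable in this measurement. The change in structure is far from small: a five-membered aromatic ring with no hydrogen-bond donor leaves, and a chain with no ring, a double bond outside aromatic rings and a hydrogen-bond donor enters, yet the two numbers remain within the scatter of each other. Nothing measured here explains this match between two such different groups.

One step cannot show whether this position accepts many kinds of group or whether these two simply happen to give similar numbers. Still open, as far as these compounds go, is how the number would respond to a shorter or longer chain ending in the same carboxylic acid, to the methyl ester of that acid, or to an amine at the end of the chain.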